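The source may report more compounds than this note shows. Statements on the series, on what has been measured and on what is new or still open speak of the compounds shown alone.

Measured in a functional assay on Malme-3M cells (Homo sapiens) for cytotoxicity, read by MTT assay, with a stated time of 6 days; a higher number here means that more compound is needed for the effect, a lower number that less compound is needed
Compound 1 `COC(=O)c1c(-c2ccc(OCc3ccccc3)cc2)oc2ccccc2c1=O` gives > 25 ug/mL
Compound 2 `CC(=O)Nc1ccc(-c2cc(=O)c3c(OC(C)=O)cc(OC(C)=O)cc3o2)cc1` gives > 25 ug/mL

Both entries are limits and not numbers. Compound 2 stands at the limit of > 25 ug/mL in this assay, at which 2 of the 2 values shown sit, and so has no exact place in the series. Among the measured compounds shown here, compound 3 `CC(=O)Nc1ccc(-c2cc(=O)c3ccc(OC(C)=O)cc3o2)cc1` carries hydrogen in place of acetoxy on an aromatic carbon and no measured step covers this change. The only anchor is the limit of compound 2 (> 25 ug/mL) so the expected a number no higher from compound 2 to compound 3 (the limit leaves the size open) stays within the usual scatter, with no favoured direction. For compound 3 the estimated value is 25 ug/mL with a range from 10 ug/mL to 50 ug/mL in the same read-out.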

Compound 3, concentration for half-maximal effect: > 25 ug/mL
Compound 3: a limit, no number; the forecaster's own chance of this, stated with the estimate: 70%; the middle value lies on the limit itself.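

Compound 2 and compound 3 are both limits, not numbers, in this assay, and no step between them can be read: the limit of > 25 ug/mL in this assay, at which 3 of the 3 values shown sit.

The compounds shown leave open what effect, if any, hydrogen in place of acetoxy has in this assay, as none of them gives an exact value.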